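Swapping Methyl for Tert-Butyl on a Thiazolidinedione Benzyl Group

This account rests on a few compounds, and the source may have more. Where it says the series, first, only, none or still open, it means among the compounds named here.

Measured compounds:
Compound 1, `C=C(Br)C(=O)Nc1cccc(/C=C2\SC(=O)N(Cc3ccc(C)cc3)C2=O)c1`, gives 600 nM.
Compound 2, `C=C(Br)C(=O)Nc1ccc(/C=C2\SC(=O)N(CC)C2=O)cc1`, gives 500 nM.
Compound 3, `Nc1cccc(/C=C2\SC(=O)N(Cc3ccccc3)C2=O)c1`, gives 233000 nM.

These three compounds were tested in a functional assay on L1210 cells (Mus musculus) for cytotoxicity, read by cell counting, with a stated time of 2 days; on this read-out lower numbers stand for stronger inhibition and higher numbers for weaker inhibition. Among the three numbers, compound 1 stands second highest. Its nearest neighbour is compound 2, whose number is within the usual scatter of compound 1, so the two cannot be told apart. Compound 3 gives a far higher number, well beyond the scatter, and is thus the weakest of the three.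

Compound 4, `C=C(Br)C(=O)Nc1cccc(/C=C2\SC(=O)N(Cc3ccc(C(C)(C)C)cc3)C2=O)c1`, has not yet been measured. It differs from compound 1 in a single place: tert-butyl in place of methyl on an aromatic carbon. The shared core of compound 1 stays untouched, and the group that changes sits far out on the benzyl arm.

Within the data shown here, no measured pair in this set shows the effect of growing a substituent at that position, so nothing here points to a direction. A step of this kind is expected to stay within the scatter, or close to it. Compound 4 is therefore estimated at 600 nM, with a range from 200 nM to 2000 nM, which means an expected step of no change at the digits printed from compound 1 to compound 4 (within the scatter).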

Compound 4, half-maximal inhibitory concentration: 3200 nM
For compound 4 the middle estimate is 5.3-fold (0.73 log units) below the measured one; the whole stated range lies below it.
By their numbers in this assay, from the lowest: compounds 2 and 1 (each within the scatter of the next); then compound 4; then compound 3.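

In this assay the change gives a 5.3-fold higher number from compound 1 to compound 4 (0.73 log units; beyond the scatter) and so shows that the far end of the benzyl arm is not a free spot, where any group could be placed without consequence. The swap of methyl for tert-butyl adds only carbon, with no hydrogen-bond donor, no hydrogen-bond acceptor and no net charge on either side, yet even this plain hydrocarbon change moves the number beyond the usual scatter, towards weaker inhibition. No measurement in hand explains why the number rises with this swap.

Methyl and tert-butyl are only two points, so the compounds shown leave open whether the number climbs steadily as the group grows, which an ethyl or isopropyl group at the same carbon would help to settle. They also leave open how this position responds to groups of a different kind, such as a methoxy group, an amine or a carboxylic acid, and whether a plain hydrogen there would read differently from methyl.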